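This account rests on a few compounds, and the source may have more. Where it says the series, first, only, none or still open, it means among the compounds named here.

The measured compounds are:

compound 1, `O=C1C(O)=C(C(c2cccc([N+](=O)[O-])c2)c2c[nH]c3ccccc23)C(=O)c2ccccc21`, 24900 nM in a functional assay on HeLa cells (Homo sapiens) for cytotoxicity, read by MTT assay, with a stated time of 48 h; a higher number here means a weaker inhibitor, a lower number a stronger inhibitor
compound 2, `COc1cccc(C(C2=C(O)C(=O)c3ccccc3C2=O)c2c[nH]c3ccccc23)c1`, 25600 nM
compound 3, `O=C1C(O)=C(C(c2ccccc2)c2c(-c3ccccc3)[nH]c3ccccc23)C(=O)c2ccccc21`, 18800 nM

All three share one core and differ only in the aryl group on the saturated chain carbon or in the substituent on the indole. The three numbers in this assay lie close together: compound 2 is separated from compound 1 and from compound 3 by gaps that both fall within the scatter, so no ordering among them can be read from these data.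

Compound 4, `O=C1C(O)=C(C(c2cccs2)c2c[nH]c3ccccc23)C(=O)c2ccccc21`, has not yet been measured. It differs from compound 2 as follows: thiophen-2-yl in place of 3-methoxyphenyl on a saturated chain carbon bound to an aromatic carbon and a double-bonded ring carbon.

Going by the values given here, only one measured step bears on this change. The step from compound 1 to compound 2 replaced one group on the aromatic ring at this position and gave a 1.0-fold higher number from compound 1 to compound 2 (0.01 log units; within the scatter). That step shows the aryl group at this position tolerating a change without a shift beyond the scatter, though it altered a substituent rather than the whole ring. Among the compounds with values here, no measured pair exchanges the six-membered ring for a five-membered one, so the expectation rests on that single step alone.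

Compound 4 is therefore expected to give a step of a 1.1-fold lower number from compound 2 to compound 4 (0.03 log units; within the scatter), that is, nothing beyond the scatter. The estimate for compound 4 is 24000 nM, with a range from 12000 nM to 48000 nM.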

Compound 4, half-maximal inhibitory concentration: 12400 nM
Beside the measured number, compound 4's estimate is 1.9-fold (0.29 log units) above it; measured number inside the range.
By their numbers in this assay, from the lowest: compounds 4, 3, 1 and 2 (each within the scatter of the next, the first and the last beyond it).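

In this assay, exchanging the whole 3-methoxyphenyl ring for thiophen-2-yl on the saturated chain carbon gave a 2.1-fold lower number from compound 2 to compound 4 (0.31 log units; beyond the scatter), whereas the substituent exchange on the six-membered ring had given a 1.0-fold higher number from compound 1 to compound 2 (0.01 log units; within the scatter). This position can therefore register a change of the aryl group itself, but the shift is small and depends on the comparison: the same thiophen-2-yl set against 3-nitrophenyl gives a 2.0-fold lower number from compound 1 to compound 4 (0.30 log units; within the scatter), so the gain over the six-membered aryl groups is not established for both of them. Nothing measured here accounts for the step from 3-methoxyphenyl to thiophen-2-yl.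

The compounds shown leave open whether the step belongs to the five-membered ring, to its sulfur atom or to the loss of the methoxy group, since an unsubstituted phenyl, a furan-2-yl and a thiophen-3-yl at this carbon are all absent from them. They also leave open whether an amine or a carboxylic acid carried on the thiophene ring would move the number further in this assay.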